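The source may report more compounds than this note shows. Statements on the series, on what has been measured and on what is new or still open speak of the compounds shown alone.

Among the compounds with values here, in an ADME assay on WI-38 cells (Homo sapiens) for cytotoxicity, read by MTT assay, with a stated time of 3 days (a lower number here means a stronger inhibitor, a higher number a weaker inhibitor), compound 1 `CCCCCCC#Cc1cn(C/C=C/CN2C(=O)c3ccccc3C2=O)c(=O)[nH]c1=O` gives 40000 nM, the only actual number available so far. Within the data shown here, compound 2 `O=C1c2ccccc2C(=O)N1C/C=C\Cn1cc(C#CCCc2ccccc2)c(=O)[nH]c1=O` is the sole other compound tested. Compound 2 reads > 100000 nM, which is a limit of the assay and not a number. Among the measured compounds shown here, compound 1 therefore stands alone as the single measured point, and no step between measured compounds is available to show how large a change in one place might be.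

Compound 3 `CCCCC#Cc1cn(C/C=C/CN2C(=O)c3ccccc3C2=O)c(=O)[nH]c1=O` keeps the core of compound 1 and differs in one place: hydrogen in place of ethyl on a saturated chain carbon, four bonds along the chain from a triple-bonded carbon. The same difference can be read as pentyl to propyl. With compound 1 at 40000 nM as the only anchor, the expected change in this assay is small, leaning toward weaker inhibition and probably not beyond the usual scatter. The expected move is a 1.4-fold higher number from compound 1 to compound 3 (0.14 log units; within the scatter). For compound 3 the estimated value is 55000 nM, with an expected range of 20000 nM to 100000 nM.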

Compound 3, half-maximal inhibitory concentration: 35000 nM
The estimate for compound 3 lay 1.6-fold (0.20 log units) above the measured number, and the stated range covers the measured number.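

Within the data shown here, the step gives the first measured comparison at this position. In this assay, hydrogen in place of ethyl on a saturated chain carbon, four bonds along the chain from a triple-bonded carbon, gives a 1.1-fold lower number from compound 1 to compound 3 (0.06 log units; within the scatter), so this one change, also readable as pentyl to propyl, leaves the number within the scatter while the rest of the structure stays the same. Compound 2 reads only as a limit of the assay, not as a number, and so offers no measured step to set beside this one: the limit of > 100000 nM in this assay, at which 1 of the 3 values shown sits.

What the compounds shown leave open is whether this result holds beyond a single pair, since one step within the scatter cannot describe how the whole chain behaves in this assay. A longer chain, or a chain ending in an amine or a carboxylic acid, could give a different result at this position, and nothing shown here says whether its number would stay with those of compound 1 and compound 3 or move away from them.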